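The source may report more compounds than this note shows. Statements on the series, on what has been measured and on what is new or still open speak of the compounds shown alone.

Compound 2 `CC(C)C[C@H](NC(=O)N1CCOCC1)C(=O)N[C@@H](C)C#N` stands lowest of the two numbers measured in an assay for inhibition of cathepsin S (Homo sapiens); a higher number here means a weaker inhibitor, a lower number a stronger inhibitor; in that assay compound 2 gives 142 nM. In this assay compound 3 `CC(C)CC[C@H](NC(=O)N1CCOCC1)C(=O)N[C@@H](C#N)CCc1ccccc1` gives 387 nM, a gap from compound 2 that lies beyond the usual scatter. Going by the values given here, compound 1 `CC(C)C[C@H](NC(=O)N1CCOCC1)C(=O)N[C@H](C)CCc1ccccc1` reaches only a limit of this assay and not a number, > 339000 nM, as the one value sitting at the limit (the limit of > 339000 nM in this assay, at which 1 of the 3 values shown sits). The unmeasured compound 4 `CC(C)C[C@H](NC(=O)N1CCOCC1)C(=O)NC(C)(C)C#N` differs from compound 2 in one place: 1-cyano-1-methylethyl in place of 1-cyanoethyl on an amide-type nitrogen. Among the compounds with values here, no step between two measured compounds covers this change, so the expectation rests on compound 2 alone and on the nature of the change. The expected step, a 5.6-fold higher number from compound 2 to compound 4 (0.75 log units; beyond the scatter), is thought to lie beyond the scatter and to raise the number, so compound 4 is expected to be the weaker inhibitor of the pair. Compound 4 is estimated at 800 nM in this assay, with a range from 200 nM to 4000 nM.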

Compound 4, half-maximal inhibitory concentration: 114 nM
For compound 4 the middle estimate is 7.0-fold (0.85 log units) above the measured one; measured number outside the range, below it.
By their numbers in this assay, from the lowest: compounds 4 and 2 (each within the scatter of the next); then compound 3. At a limit, above all of these: compound 1.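

In this assay, placing 1-cyano-1-methylethyl in place of 1-cyanoethyl on the amide-type nitrogen gives a 1.2-fold lower number from compound 2 to compound 4 (0.10 log units; within the scatter), so this position accepts the group with 5 heavy atoms without a separation between the two compounds. The change also removes the defined stereocentre of the 1-cyanoethyl group, and for this pair a defined stereocentre in this group is not needed to keep the number within the scatter. Nothing in the evidence at hand bears on why the two numbers stay this close.

The compounds shown leave open how a 1-cyanocyclopropyl group or a longer chain such as 1-cyano-1-methylpropyl would read on the same amide-type nitrogen. They also leave open whether the same change would read alike on the core of compound 3.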